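The source may hold more compounds than are shown below. What is called first, only, known or untested is meant among the compounds shown, and "the series" means these compounds.

Measured so far:
compound 1, `COc1ccccc1N1CCN(CCCCNC(=O)N(C)c2ccccc2)CC1`: 116 nM
compound 2, `O=C(NCCCCN1CCN(c2ccccc2Cl)CC1)c1ccc2ccccc2c1`: 29.9 nM

Both were run in an assay on isolated protein for displacement of a labelled ligand from Alpha-1A adrenergic receptor (Homo sapiens); a higher number here means a weaker inhibitor, a lower number a stronger inhibitor. For the measured compounds named here, compound 2 gives the lowest of the two numbers; compound 1 sits well apart from it, a gap beyond the usual scatter, and the two compounds differ at several places at once, so no single step joins them. Compound 3 `O=C(NCCCCN1CCN(c2cccc(C(F)(F)F)c2)CC1)c1ccc2ccccc2c1` has not yet been measured. It differs from compound 2 in one place: 3-(trifluoromethyl)phenyl in place of 2-chlorophenyl on an amine nitrogen in a ring. Going by the values given here, no pair of measured compounds carries this change, so the direction of the step is not settled by what has been measured. A small step toward a higher number is expected, one that may well stay within the usual scatter, giving a 2.0-fold higher number from compound 2 to compound 3 (0.30 log units; within the scatter). Compound 3 is expected to give 60 nM in this assay, with a range from 15 nM to 250 nM.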

Compound 3, inhibition constant: 283 nM
Compound 3: middle estimate off by 4.7-fold (0.67 log units), on the low side, and the stated range ends below it.
By their numbers in this assay, from the lowest: compound 2; then compound 1; then compound 3.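

For the compounds shown here, the aryl group on the amine nitrogen in the ring is a sensitive position in this assay: with the rest of the structure held constant, 3-(trifluoromethyl)phenyl in place of 2-chlorophenyl gives a 9.5-fold higher number from compound 2 to compound 3 (0.98 log units; beyond the scatter) and so provides the first single-place reading. The earlier pair could not show this, since compound 1 and compound 2 differ at several places at once. No available measurement bears on the origin of this step.

The change replaces chlorine with trifluoromethyl and also moves the substituent on the phenyl ring, so the compounds shown leave open which of the two carries the step. A 3-chlorophenyl or a 2-(trifluoromethyl)phenyl group on the same nitrogen would separate these two changes.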